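From 4-chlorophenyl to 2-fluorophenyl on the ethenyl chain

The source may report more compounds than this note shows. Statements on the series, on what has been measured and on what is new or still open speak of the compounds shown alone.

Measured in a functional assay on MIA PaCa-2 cells (Homo sapiens) for inhibition, read by MTT assay, with a stated time of 48 h, tested at 10 uM; on this read-out lower numbers stand for less inhibition of growth and higher numbers for more inhibition of growth at the one concentration tested:
- compound 1 `Cc1cc(=O)c2c(O)cc(OCc3ccccc3)c([C@H]3CCN(C)C[C@H]3O)c2o1` gives 14%
- compound 2 `Cc1oc2c([C@H]3CCN(C)C[C@H]3O)c(O)cc(O)c2c(=O)c1C(O)c1c(F)cccc1Cl` gives 41%
- compound 3 `CN1CC[C@H](c2c(O)cc(O)c3c(=O)cc(/C=C/c4ccc(Cl)cc4)oc23)[C@H](O)C1` gives 88%

Compound 3 stands highest of the three on this assay, and its lead over each of the other two lies beyond the scatter. Compound 2 is its nearest neighbour and compound 1 the furthest. For the measured compounds named here, compound 3 is also the only measured compound with a 2-(4-chlorophenyl)ethenyl chain, but compounds 1 and 2 differ from it in more than one place, so no measured pair isolates that chain.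

Compound 4 `CN1CC[C@H](c2c(O)cc(O)c3c(=O)cc(/C=C/c4ccccc4F)oc23)[C@H](O)C1` is the next to be read. It differs from compound 3 in one place: 2-fluorophenyl in place of 4-chlorophenyl on a double-bonded chain carbon bound to a double-bonded chain carbon. The ethenyl chain stays, and only the ring at its end changes. Going by the values given here, no measured pair shows what such a swap does, so the expectation is loose. With compound 3 at 88%, little room remains upward on this scale, and a fall is more likely than a rise. The expected change is a number 10 percentage points lower from compound 3 to compound 4 (within the scatter), a modest fall that may not clear the scatter. For compound 4 the estimated value is 78%, with an expected range from 50% to 97%.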

Compound 4, percent growth inhibition at one concentration: 60%
Beside the measured number, compound 4's estimate is 18 percentage points above it; measured number inside the range.
By their numbers in this assay, from the lowest: compound 1; then compound 2; then compound 4; then compound 3.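

In this assay, for the compounds shown here, the first pair that isolates the ring at the end of the ethenyl chain gives a number 28 percentage points lower from compound 3 to compound 4 (beyond the scatter), so this place on the chain responds to the ring it carries. The two rings match in heavy-atom, donor and acceptor counts and in net charge, so these counts do not track the step, and the change is limited to which halogen the phenyl ring carries and where it sits. No measurement in hand accounts for the fall.

The step changes the halogen and its place on the ring together, so the two remain unseparated: a 4-fluorophenyl or a 2-chlorophenyl on the same ethenyl chain would divide the step between them. Also open are how a ring bearing an amine or a carboxylic acid, or a longer chain in place of the ethenyl chain, would read, and what the ethenyl chain itself contributes, as no pair shown isolates it.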